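Extending the Alkoxy Group of Compound 3

A few compounds are considered here, and "the series" means these few. Any claim that something is new, unique, unknown or untested is made for them only; others in the source may bear on it.

Among three compounds built on one shared core, compound 3 `COc1ccc(N2C[C@@H](C)N[C@@H](C)C2)cc1NS(=O)(=O)c1ccc(-c2ccccn2)s1` gives the lowest number in a functional assay for agonist activity at growth hormone secretagogue receptor type 1 (Homo sapiens), read by FLIPR (a higher number here means that more compound is needed for the effect, a lower number that less compound is needed), at 10 nM. Among the compounds with values here, compound 1 `COc1ccc(NS(=O)(=O)c2ccc(-c3ccccn3)s2)cc1N1C[C@@H](C)N[C@@H](C)C1` lies within the scatter of it with 15.9 nM, while compound 2 `C[C@@H]1CN(c2cc(NS(=O)(=O)c3ccc(-c4ccccn4)s3)ccc2C#N)C[C@H](C)N1` stands far apart at 631 nM; the single measured step, a 40-fold higher number from compound 1 to compound 2 (1.60 log units; beyond the scatter), concerns the exchange of methoxy for cyano. Compound 4 `CC(C)Oc1ccc(N2C[C@@H](C)N[C@@H](C)C2)cc1NS(=O)(=O)c1ccc(-c2ccccn2)s1` differs from compound 3 by isopropyl in place of methyl on an oxygen on an aromatic ring. Within the data shown here, no measured step touches that oxygen, so the cyano step offers no guide, and a step beyond the scatter in this assay is not expected in either direction. Compound 3 is the anchor. For compound 4 an estimate of 12 nM in this assay is expected, with a range of 4 nM to 40 nM. The expected step is a 1.2-fold higher number from compound 3 to compound 4 (0.08 log units; within the scatter).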

Compound 4, half-maximal effective concentration: 100 nM
For compound 4 the middle estimate is 8.3-fold (0.92 log units) below the measured one, outside the stated range (above it).
By their numbers in this assay, from the lowest: compounds 3 and 1 (each within the scatter of the next); then compound 4; then compound 2.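

At this oxygen on an aromatic ring, the change from methoxy to isopropoxy gives a 10-fold higher number from compound 3 to compound 4 (1.00 log units; beyond the scatter) in this assay, so the position does respond to the group it carries. The isopropyl that enters adds only carbon, with no ring, hydrogen-bond donor, hydrogen-bond acceptor or net charge, so a change of carbon count alone is enough for a step beyond the scatter. Nothing available here accounts for this rise.

The compounds shown leave open how ethoxy would read at this oxygen. They also leave open whether a longer chain ending in an amine would read differently from isopropyl.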